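The source may report more compounds than this note shows. Statements on the series, on what has been measured and on what is new or still open speak of the compounds shown alone.

Series notes. Compound 1 (`CCCCCCCCCCCCOc1ccc(C(=O)/C=C/c2c(/C=C/c3ccc(OC)cc3)cc(OC)cc2OC)cc1`) gives 11.6 ug/mL in a functional assay on HepG2 cells (Homo sapiens) for antiproliferative activity, read by MTT assay, with a stated time of 48 h (on this read-out lower numbers stand for stronger inhibition and higher numbers for weaker inhibition), and compound 2 (`COc1ccc(/C=C/c2cc(OC)cc(OC)c2/C=C/C(=O)c2cccc(OC)c2)cc1`) gives 11.6 ug/mL there, so compound 2 stands level with compound 1 within the scatter. For the measured compounds named here, compound 3 (`COc1ccc(/C=C/c2cc(OC)cc(OC)c2/C=C/C(=O)c2ccc(C)cc2)cc1`) has no measurement yet. It differs from compound 2 by 4-methylphenyl in place of 3-methoxyphenyl on a carbonyl carbon with 4-methylphenyl in place of 3-methoxyphenyl on a carbonyl carbon. Going by the values given here, no step between measured compounds exists to size this change, and the two measured values suggest no direction. The step of a 1.0-fold higher number from compound 2 to compound 3 (0.01 log units; within the scatter) is therefore expected to stay within the scatter in this assay with neither direction favoured. The estimate is anchored on compound 2 at 11.6 ug/mL for want of any closer guide. Compound 3 is estimated at 12 ug/mL with an expected range from 5 ug/mL to 30 ug/mL for now.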

Compound 3, half-maximal inhibitory concentration: 4.8 ug/mL
The estimate for compound 3 lay 2.5-fold (0.40 log units) above the measured number; the measured number lies below the stated range.
By their numbers in this assay, from the lowest: compound 3; then compounds 1 and 2 (each within the scatter of the next).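

Carrying 4-methylphenyl in place of 3-methoxyphenyl on the carbonyl carbon gives a 2.4-fold lower number from compound 2 to compound 3 (0.38 log units; beyond the scatter) in this assay, the first sized step in the series and one beyond the scatter. It shows that the number at this position responds to the aryl group carried there, which the two earlier values alone could not show. No measured evidence bears on the reason for the shift.

Going by these compounds, the step exchanges the methoxy group for a methyl group and changes the printed ring position in one move, so the share of each remains open. On these data alone, how a plain phenyl, a 4-chlorophenyl or a 4-aminophenyl group would read at this carbonyl carbon also remains open, as does whether 4-methylphenyl would give the same step on another core.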